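A Pyridinyl Sulfonamide Set Against Three Unresolved Limits

The source may report more compounds than this note shows. Statements on the series, on what has been measured and on what is new or still open speak of the compounds shown alone.

The study centres on compound 2 `CC(C)(C)c1ccc(CN(Cc2cccc(CCC(=O)O)c2)S(=O)(=O)c2ccc(Cl)cc2)cc1`, tested in an assay on HEK293 cells for inhibition of prostaglandin E2 receptor EP4 subtype (Rattus norvegicus); a higher number here means a weaker inhibitor, a lower number a stronger inhibitor. In this assay compound 2 gives > 3200 nM, which is a limit of the assay and not a number. Its neighbour compound 1 `CC(C)(C)c1ccc(CN(Cc2cccc(CCC(=O)O)c2)S(=O)(=O)c2nccs2)cc1` carries a 1,3-thiazol-2-yl group on the sulfonyl sulfur. In this assay compound 1 gives > 3200 nM, again a limit rather than a number. A third member, compound 3 `Cn1ccnc1CS(=O)(=O)N(Cc1ccc(C(C)(C)C)cc1)Cc1cccc(OCC(=O)O)c1`, is built around a different acid-bearing side. In this assay compound 3 gives > 3200 nM, also a limit. Going by the values given here, the one step between two measured compounds, a step that the two limits leave unreadable from compound 1 to compound 2, cannot be read, since both ends sit at the same limit; this is what the limit of > 3200 nM in this assay, at which 3 of the 3 values shown sit, records.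

Compound 4 `CC(C)(C)c1ccc(CN(Cc2cccc(CCC(=O)O)c2)S(=O)(=O)c2ccccn2)cc1` differs from compound 2 in one place: pyridin-2-yl in place of 4-chlorophenyl on a sulfonyl sulfur. Among the compounds with values here, the only measured step that bears on an aryl-to-heteroaryl exchange at this position is the unreadable one from compound 1 to compound 2, so no size can be borrowed from it. With every value shown sitting at the limit, a shift in this assay that would lift compound 4 clearly above the scatter is not expected, and the step that the limit leaves unreadable from compound 2 to compound 4 is estimated to be essentially flat. Compound 4 is therefore expected to give about 6000 nM, within a range of 2000 nM to 20000 nM, most likely reported only as a limit.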

Compound 4, half-maximal inhibitory concentration: > 3200 nM
Compound 4 gave a limit, no number; the forecaster's own chance of this, stated with the estimate: 80%; the middle value is on the limit's open side.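

In this assay compound 4 gives > 3200 nM, a limit and not a number. No step from compound 1 or compound 2 to compound 4 can be read, because all three sit at the same limit: the limit of > 3200 nM in this assay, at which 4 of the 4 values shown sit.

The compounds shown leave open how 4-chlorophenyl, 1,3-thiazol-2-yl and pyridin-2-yl on the sulfonyl sulfur compare in this assay.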